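Benzyl ether series: cytotoxicity notes toward compound 4

This account rests on a few compounds, and the source may have more. Where it says the series, first, only, none or still open, it means among the compounds named here.

Measured compounds:
compound 1, `N#Cc1ccccc1COc1c(-c2ccccc2)oc2cc(O)cc(O)c2c1=O`: in an ADME assay on Huh-5-2 cells (Homo sapiens) for cytotoxicity, read by WST assay, with a stated time of 3 days (a lower number here means that less compound is tolerated, a higher number that more compound is tolerated), compound 1 gives > 100000 nM, a limit of the assay.
compound 2, `Cc1ccccc1COc1c(-c2ccccc2)oc2cc(O)cc(O)c2c1=O`: compound 2 gives 55000 nM.
compound 3, `O=c1c(OCc2cccc(Br)c2)c(-c2ccccc2)oc2cc(O)cc(O)c12`: compound 3 gives 15000 nM.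

Compound 3 stands lowest of the two numbers in this assay; compound 2 is nearest, the gap being a 3.7-fold lower number from compound 2 to compound 3 (0.56 log units; beyond the scatter). Compound 1 sits at the limit of > 100000 nM in this assay, at which 1 of the 3 values shown sits.

Compound 4, `N#Cc1cccc(COc2c(-c3ccccc3)oc3cc(O)cc(O)c3c2=O)c1`, differs from compound 3 by cyano in place of bromo on an aromatic carbon. The steps of an at least 6.6-fold lower number from compound 1 to compound 3 (0.82 log units; beyond the scatter) and a 3.7-fold lower number from compound 2 to compound 3 (0.56 log units; beyond the scatter) bear on it: both move from a ring without bromo to 3-bromophenyl and lower the number, so removing bromo for cyano, a group also present in compound 1, is expected to raise it. Compound 4 is therefore expected near 60000 nM, within 20000 nM to 200000 nM, an expected 4.0-fold higher number from compound 3 to compound 4 (0.60 log units; beyond the scatter).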

Compound 4, half-maximal cytotoxic concentration: 21000 nM
For compound 4 the middle estimate is 2.9-fold (0.46 log units) above the measured one; the measured number falls inside the stated range.
By their numbers in this assay, from the lowest: compounds 3 and 4 (each within the scatter of the next); then compound 2. At a limit, above all of these: compound 1.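

Cyano in place of bromo on this aromatic carbon gives no readable shift in this assay (a 1.4-fold higher number from compound 3 to compound 4 (0.15 log units; within the scatter)), so the low number is not tied to bromo alone, and 3-cyanophenyl keeps a gap to the 2-methylphenyl ring (a 2.6-fold lower number from compound 2 to compound 4 (0.42 log units; beyond the scatter)). With the nitrile kept, 3-cyanophenyl in place of 2-cyanophenyl still separates the two compounds (an at least 4.7-fold lower number from compound 1 to compound 4 (0.67 log units; beyond the scatter)), so among these compounds the nitrile alone does not set the number. That step is a floor, since the value of compound 1 is a limit of the assay: the limit of > 100000 nM in this assay, at which 1 of the 4 values shown sits.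

From the compounds shown here alone, whether an amine or a carboxylic acid in place of cyano would stay with compound 3 and compound 4 remains open.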